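The compounds below may be only part of what the source reports. "The series", "measured", "known", "first", "only" and "open" are said of these compounds alone.

Values measured in a functional assay on MCF7 cells (Homo sapiens) for antiproliferative activity, read by MTT assay, with a stated time of 48 h (on this read-out higher numbers stand for weaker inhibition and lower numbers for stronger inhibition), follow.

Compound 1 `CCCCCCCCCCCCCCn1cc(COC[C@@H]2OC[C@H](N)[C@@H]2O)nn1` gives 1850 nM
Compound 2 `CCCCCCCCn1cc(COC[C@@H]2OC[C@H](N)[C@H]2O)nn1` gives only a limit, > 128000 nM
Compound 3 `CCCCCCCCCn1cc(COC[C@@H]2OC[C@H](N)[C@H]2O)nn1` gives only a limit, > 128000 nM

Compound 3 sits at the limit of > 128000 nM in this assay, at which 2 of the 3 values shown sit. Compound 4 `CCCCCCCCCCCCCCn1cc(COC[C@@H]2OC[C@H](N)[C@H]2O)nn1` follows from compound 3 by pentyl in place of hydrogen on a saturated chain carbon, nine bonds along the chain from an aromatic nitrogen. Going by the values given here, the only measured step is a step that the two limits leave unreadable from compound 2 to compound 3, so it offers no size to carry over. The chain of compound 4 also stands on a differently arranged core in the closest guide, and that guide, compound 1, gives 1850 nM. A large move toward stronger inhibition in this assay is therefore expected, an estimated at least 21-fold lower number from compound 3 to compound 4 (1.32 log units; beyond the scatter). For compound 4 the expected value is 6000 nM, with an estimated range of 1500 nM to 40000 nM.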

Compound 4, half-maximal inhibitory concentration: 2450 nM
Estimate against measurement, compound 4: 2.4-fold (0.39 log units) above; low and high end bracket the measured number.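

In this assay, extending the chain gives a readable value on this core: pentyl in place of hydrogen on a saturated chain carbon, nine bonds along the chain from an aromatic nitrogen, gives an at least 52-fold lower number from compound 3 to compound 4 (1.71 log units; beyond the scatter), and the same chain counted as hexyl gives an at least 52-fold lower number from compound 2 to compound 4 (1.71 log units; beyond the scatter). Both steps start from a limit of the assay, not a number. Inverting the stereocentre at a saturated ring carbon gives a 1.3-fold higher number from compound 1 to compound 4 (0.12 log units; within the scatter), so with this chain the configuration does not separate the two compounds.

The compounds shown leave open at which chain length between those of compound 3 and compound 4 a readable value first appears. They also leave open whether a longer chain, or an amine at the chain end, would keep it.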